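Swapping Methoxyphenyl for Benzodioxinyl on a Weak Amide

A few compounds are considered here, and "the series" means these few. Any claim that something is new, unique, unknown or untested is made for them only; others in the source may bear on it.

Compound 1 `Cc1ccc(Nc2ncc3c(n2)N(C)C(=O)N(c2cc(NC(=O)c4cccc(C(F)(F)F)c4)ccc2C)C3)cc1N(C)C`: in an ADME assay on BaF3 cells (Mus musculus) for antiproliferative activity, read by CellTiter-Glo and CCK-8 assay, with a stated time of 72 h (a higher number here means a weaker inhibitor of growth, a lower number a stronger inhibitor of growth), compound 1 reaches only the assay limit, > 10000 nM.
Compound 2 `CNc1nc(Nc2ccc(C)c([N+](=O)[O-])c2)ncc1C(=O)Nc1cc(NC(=O)c2cccc(OC)c2)ccc1C`: in this assay compound 2 gives 6310 nM.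

Among the measured compounds shown here, compound 2 therefore carries the only real number among the two values shown. The result for compound 1 is the limit of > 10000 nM in this assay, at which 1 of the 2 values shown sits, a limit and not a number, so compound 1 and compound 2 cannot be ranked against each other with confidence.

Compound 3 `CNc1nc(Nc2ccc(C)c([N+](=O)[O-])c2)ncc1C(=O)Nc1cc(NC(=O)c2ccc3c(c2)OCCO3)ccc1C` differs from compound 2 in one place: 2,3-dihydro-1,4-benzodioxin-6-yl in place of 3-methoxyphenyl on a carbonyl carbon. For the measured compounds named here, no measured pair of compounds shows what such a swap does, so the expectation rests on compound 2 alone. The step from compound 2 to compound 3 is expected to be a 1.0-fold higher number from compound 2 to compound 3 (0.01 log units; within the scatter), which amounts to no change beyond the usual scatter. Compound 3 is accordingly estimated at 6500 nM, with a plausible range from 2000 nM to 20000 nM, and a real chance that only a limit is reported.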

Compound 3, concentration for 50% growth inhibition: > 10000 nM
Compound 3: no number, only a limit; the forecaster's own chance of this, stated with the estimate: 35%; at least 1.5-fold (0.18 log units) between middle value and limit.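

Putting 2,3-dihydro-1,4-benzodioxin-6-yl in place of 3-methoxyphenyl on this carbonyl carbon gives an at least 1.5-fold higher number from compound 2 to compound 3 (0.19 log units; that floor lies within the scatter). On these data alone, compound 3 reaches only a limit and not a number, so the true size of this step remains unknown, and the change shows no sign of a stronger inhibitor of growth in this assay. Most of the results shown now rest at that ceiling: the limit of > 10000 nM in this assay, at which 2 of the 3 values shown sit.

As far as these compounds go, it remains open how far compound 3 really lies from compound 2, and whether any group on this carbonyl carbon can improve on compound 2, at 6310 nM. The compounds shown also do not reveal what a phenyl ring carrying an amine or a carboxylic acid would do at this place.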